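The source may report more compounds than this note shows. Statements on the series, on what has been measured and on what is new or still open speak of the compounds shown alone.

Of the compounds shown here, three have been measured in a functional assay on HCT-116 cells (Homo sapiens) for antiproliferative activity, read by MTT assay, with a stated time of 72 h; a higher number here means a weaker inhibitor, a lower number a stronger inhibitor: compound 1, `O=S1(=O)C=Cc2ccc(Nc3ccc(C(F)(F)F)cc3)cc21`, gives 1340 nM; compound 2, `COc1ccc(Nc2ccc3c(c2)S(=O)(=O)C=C3)cc1`, gives 1170 nM; compound 3, `COc1ccccc1Nc1cccc2c1S(=O)(=O)C=C2`, gives 5000 nM.

Compound 2 and compound 1 differ in one place, (trifluoromethyl in place of methoxy on an aromatic carbon), and the step between them, a 1.1-fold higher number from compound 2 to compound 1 (0.06 log units; within the scatter), is small. Compound 3 shares its atoms with compound 2 but has them joined differently; the difference between the two cores is not broken down here. In this assay compound 3 stands highest of the three, beyond the scatter from both compound 1 and compound 2.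

Compound 4, `O=S1(=O)C=Cc2cccc(Nc3ccccc3C(F)(F)F)c21`, has not been measured. It differs from compound 3 by trifluoromethyl in place of methoxy on an aromatic carbon, the same kind of change as that from compound 2 to compound 1, though not the same: in compound 1 the trifluoromethyl sits para to a large group, in compound 4 ortho to a large group. In this assay the step from compound 3 to compound 4 is expected to be a 1.1-fold higher number from compound 3 to compound 4 (0.04 log units; within the scatter), resting on the small step of a 1.1-fold higher number from compound 2 to compound 1 (0.06 log units; within the scatter). Compound 4 is therefore estimated at 5500 nM, with a range from 2500 nM to 12000 nM.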

Compound 4, half-maximal inhibitory concentration: 5950 nM
Compound 4: the middle estimate sits 1.1-fold (0.03 log units) below what was measured; the measured number falls inside the stated range.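

In this assay, putting trifluoromethyl in place of methoxy on the core of compound 3 gives a 1.2-fold higher number from compound 3 to compound 4 (0.08 log units; within the scatter), a step as small as the one seen on the other core. The two steps agree: the same change on two cores in this assay, a 1.1-fold higher number (0.06 log units; within the scatter) from compound 2 to compound 1 and a 1.2-fold higher number (0.08 log units; within the scatter) from compound 3 to compound 4, 1.0-fold (0.02 log units) apart, within the scatter of two such steps. Within the data shown here, in this series, then, the finding that this exchange leaves the number within the scatter carries from one core to the other, but it rests on only two pairs, in one assay, and it does not show that the result would hold on a further core, or why either step is small.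

The compounds shown leave open whether a different group on that aromatic carbon, such as an amine, a carboxylic acid or a nitrile, would move the number beyond the scatter. They also leave open what a plain hydrogen there would give, and whether methoxy and trifluoromethyl would still match at other places on that ring.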